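This account rests on a few compounds, and the source may have more. Where it says the series, first, only, none or still open, it means among the compounds named here.

Of the compounds shown here, two have so far been measured in a functional assay for inhibition, with a stated time of 24 h, tested at 100 ug/mL; on this read-out lower numbers stand for less inhibition and higher numbers for more inhibition at the one concentration tested (going by the name of the read-out). Compound 1 `CCC(c1ccc(O)c(O)c1)c1ccc(O)c(OC)c1` gives 96% in this assay. Compound 2 `CCC(c1ccc(O)c(OC)c1)c1ccccc1O` gives 94% in this assay, a number within the scatter of that of compound 1, so the two cannot be told apart. Compound 3 `CCC(c1ccc(O)c(OC)c1)c1cccc(O)c1O` has not yet been measured. It differs from compound 2 by hydroxy in place of hydrogen on an aromatic carbon. For the measured compounds named here, no step between measured compounds is known to guide the expectation. Because compound 2 already gives 94%, little room remains, and the expected step is no change at the digits printed from compound 2 to compound 3 (within the scatter), none beyond the scatter. Compound 3 is therefore expected to give about 94% in this assay, within 84% to 99%.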

Compound 3, a percentage reported as inhibition, at one concentration (the size of the read-out at that concentration, not a potency): 94%
The estimate for compound 3 equals the measured number at the digits printed; low and high end bracket the measured number.
By their numbers in this assay, from the lowest: compounds 2, 3 and 1 (each within the scatter of the next).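

In this assay, hydroxy in place of hydrogen on an aromatic carbon, ortho to a hydroxy group and meta to a large group, gives no change at the digits printed from compound 2 to compound 3 (within the scatter) in this series. This position therefore accepts the added hydroxy with the number still close to the top of the scale, although the small room left above compound 2 would hide any gain. Going by these compounds, whether an amine or a carboxylic acid at this position would hold the number stays open, as does any difference between compound 2 and compound 3 at lower concentrations. Nothing at hand explains the result.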